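This account rests on a few compounds, and the source may have more. Where it says the series, first, only, none or still open, it means among the compounds named here.

Among the measured compounds shown here, compound 3 `O=C(Nc1ccc(Br)cc1)c1cn(-c2ccccc2)nc1-c1ccc([N+](=O)[O-])cc1` gives 5300 nM in a functional assay on MCF7 cells (Homo sapiens) for cytotoxicity, read by MTT assay, with a stated time of 48 h (a higher number here means a weaker inhibitor, a lower number a stronger inhibitor), the highest of the three numbers so far. Compound 1 `CCOc1ccc(NC(=O)c2cn(-c3ccccc3)nc2-c2ccccc2)cc1` gives 880 nM, and compound 2 `CCOc1ccc(NC(=O)c2cn(-c3ccccc3)nc2-c2ccc(OC)cc2)cc1` gives 1100 nM. The gap from each of these two to compound 3 is beyond the scatter. Compound 4 `CCOc1ccc(NC(=O)c2cn(-c3ccccc3)nc2-c2ccc([N+](=O)[O-])cc2)cc1` is compound 3 with ethoxy in place of bromo on an aromatic carbon, so that compound 4 carries the same 4-ethoxyphenyl amide as compound 1 and compound 2. For the measured compounds named here, no measured step covers this exchange; the only step, a 1.3-fold higher number from compound 1 to compound 2 (0.10 log units; within the scatter), sits elsewhere and is within the scatter. Compound 1 and compound 2 both share the ethoxy group and sit well below compound 3, so a lower number is expected for compound 4, estimated as a 2.7-fold lower number from compound 3 to compound 4 (0.42 log units; beyond the scatter), with wide uncertainty. Compound 4 is thus expected near 2000 nM, between 700 nM and 6000 nM.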

Compound 4, half-maximal inhibitory concentration: 460 nM
Compound 4: middle estimate off by 4.3-fold (0.64 log units), on the high side; measured number outside the range, below it.
By their numbers in this assay, from the lowest: compounds 4, 1 and 2 (each within the scatter of the next, the first and the last beyond it); then compound 3.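

In this assay, among the compounds shown here, exchanging bromo for ethoxy on the amide aryl ring, with the nitro group held, gives a 12-fold lower number from compound 3 to compound 4 (1.06 log units; beyond the scatter) and is the first step showing that this position strongly affects the number. Nitro in place of methoxy on the other aryl ring gives a 2.4-fold lower number from compound 2 to compound 4 (0.38 log units; beyond the scatter) beyond the scatter, whereas nitro in place of hydrogen gives a 1.9-fold lower number from compound 1 to compound 4 (0.28 log units; within the scatter) and cannot be read as a change. No evidence on the cause of these steps is available. Open, going by these compounds, is whether an amine, a carboxylic acid or a longer chain at the ethoxy position would keep the number low.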